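The source may report more compounds than this note shows. Statements on the series, on what has been measured and on what is new or still open speak of the compounds shown alone.

Compound 1, `CC1CCN(C2CCN(S(=O)(=O)c3cccc(N)c3)CC2)CC1`: 3400 nM
Compound 2, `CC1CCN(C2CCN(S(=O)(=O)c3cccnc3F)CC2)CC1`: > 5000 nM (a limit)
Compound 3, `CC1CCN(C2CCN(S(=O)(=O)c3nccn3C)CC2)CC1`: > 5000 nM (a limit)

Within the data shown here, in a functional assay on DLD-1 cells (Homo sapiens) for antiproliferative activity, read by CellTiter-Glo, with a stated time of 72 h (on this read-out lower numbers stand for stronger inhibition and higher numbers for weaker inhibition), compound 1 gives 3400 nM, the only plain number in the set. For compound 2 this assay returns only a limit, > 5000 nM. For compound 3 it likewise returns only a limit, > 5000 nM, so compound 3 sits at the limit of > 5000 nM in this assay, at which 2 of the 3 values shown sit, without a number of its own.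

Compound 4, `CC1CCN(C2CCN(S(=O)(=O)c3ccc(Cl)nc3)CC2)CC1`, differs from compound 3 in a single place: 6-chloropyridin-3-yl in place of 1-methyl-1H-imidazol-2-yl on a sulfonyl sulfur. Among the measured compounds shown here, two measured steps bear on this change. The step of an at least 1.4-fold higher number from compound 1 to compound 3 (0.16 log units; that floor lies within the scatter) and the step that the two limits leave unreadable from compound 2 to compound 3 both run into the limit, so neither gives a readable size. Compound 2, which also carries a pyridinyl group on the sulfonyl sulfur, stands at the same limit as compound 3. With both limit-bound neighbours, no step beyond the scatter is expected in this assay for compound 4; the step is estimated as a step that the limit leaves unreadable from compound 3 to compound 4. Compound 4 is therefore expected to give about 6000 nM in this assay, within a range from 2500 nM to 20000 nM.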

Compound 4, half-maximal inhibitory concentration: 3700 nM
For compound 4 the middle estimate is 1.6-fold (0.21 log units) above the measured one, within the range that was stated.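

Compound 4 shows that a pyridinyl group on the sulfonyl sulfur can give a plain number in this assay, which compound 2 did not show. The steps of an at least 1.3-fold lower number from compound 3 to compound 4 (0.13 log units; that floor lies within the scatter) and an at least 1.3-fold lower number from compound 2 to compound 4 (0.13 log units; that floor lies within the scatter) are only floors, so they support no claim of a real gain for 6-chloropyridin-3-yl over either group it replaces. The step of a 1.1-fold higher number from compound 1 to compound 4 (0.04 log units; within the scatter) shows something new: at this place, 6-chloropyridin-3-yl and 3-aminophenyl cannot be told apart.

Going by these compounds, compound 2 and compound 3 have no numbers of their own, so how far they lie from compound 4 remains open: the limit of > 5000 nM in this assay, at which 2 of the 4 values shown sit. On these data alone, it also remains open whether an amine or a methoxy group in place of the chlorine on the pyridine ring would move the value beyond the scatter.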